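A few compounds are considered here, and "the series" means these few. Any claim that something is new, unique, unknown or untested is made for them only; others in the source may bear on it.

Measured in an assay on CHO cells for binding affinity to melanin-concentrating hormone receptor 1 (Homo sapiens); on this read-out higher numbers stand for weaker inhibition and lower numbers for stronger inhibition:
- compound 1 `CN1CCN(CCCN(C(=O)Nc2ccc(F)c(Cl)c2)C2CCc3ccccc3C2)CC1` gives 380 nM
- compound 2 `CN1CCN(CCCN(C(=O)Nc2ccc(F)c(Cl)c2)C2CCc3cc(Br)ccc3C2)CC1` gives 180 nM
- compound 3 `COc1ccc2c(c1)CCC(N(CCCN1CCN(C)CC1)C(=O)Nc1ccc(F)c(Cl)c1)C2` gives 190 nM

Compound 1 carries the unsubstituted core and stands at the highest number of the three; its gap to compound 3 lies within the scatter, while a 2.1-fold lower number from compound 1 to compound 2 (0.32 log units; beyond the scatter) is beyond it, if only modestly.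

Compound 4 `CN1CCN(CCCN(C(=O)Nc2ccc(F)c(Cl)c2)C2CCc3ccc(S(C)(=O)=O)cc3C2)CC1` is not yet measured. Change from compound 1: methylsulfonyl in place of hydrogen on an aromatic carbon. Among the compounds with values here, the steps that bear on it are the two other aromatic substitutions of the same core: a 2.1-fold lower number from compound 1 to compound 2 (0.32 log units; beyond the scatter) and a 2.0-fold lower number from compound 1 to compound 3 (0.30 log units; within the scatter). Both point the same way, downward and small. Within the data shown here, no measured step covers a methylsulfonyl group, so a step of similar size or none beyond the scatter is expected, a 1.5-fold lower number from compound 1 to compound 4 (0.18 log units; within the scatter). Compound 4 is therefore estimated at 250 nM in this assay, with a range of 100 nM to 700 nM.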

Compound 4, inhibition constant: 1300 nM
Beside the measured number, compound 4's estimate is 5.2-fold (0.72 log units) below it; the measured number lies above the stated range.
By their numbers in this assay, from the lowest: compounds 2, 3 and 1 (each within the scatter of the next, the first and the last beyond it); then compound 4.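

Methylsulfonyl on the aromatic carbon gives an upward step in this assay (a 3.4-fold higher number from compound 1 to compound 4 (0.53 log units; beyond the scatter)), the opposite direction to bromo (a 2.1-fold lower number from compound 1 to compound 2 (0.32 log units; beyond the scatter)). Substitution on this aromatic ring therefore does not only hold or lower the number, although this upward step remains modest. No evidence at hand accounts for the rise.

Still open, going by these compounds, is whether the change of direction follows the group or its place on the ring, as the substituents do not all sit on the same aromatic carbon. An amine or a carboxylic acid at the methylsulfonyl carbon would show whether the upward step extends to other groups.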